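The source may report more compounds than this note shows. Statements on the series, on what has been measured and on what is new or still open speak of the compounds shown alone.

Measured compounds:
compound 1, `COc1cc(-n2c(-c3ccccc3)cc(/C=C3\SC(=O)NC3=O)c2-c2ccccc2)ccc1-c1ccc(/C=C2\SC(=O)NC2=O)cc1`, 787 nM
compound 2, `COc1cc(-n2c(C)cc(/C=C3\SC(=O)NC3=O)c2C)ccc1-c1ccc(/C=C2\SC(=O)NC2=O)cc1`, 2140 nM
compound 3, `Cc1cc(/C=C2\SC(=O)NC2=O)c(C)n1-c1ccc(Br)cc1`, > 100000 nM

These three compounds were tested in an assay for inhibition of glutaminase liver isoform, mitochondrial (Homo sapiens), read by coupled enzyme assay, with stated times of 10 min and 60 min; a higher number here means a weaker inhibitor, a lower number a stronger inhibitor. Compound 2 gives 2140 nM, the higher of the two numbers that are plain values, so it is the weaker of those two; compound 1 gives 787 nM, a lower number, and the gap between them lies beyond the usual scatter. Compound 3 reaches only the limit of this assay, > 100000 nM, which is a limit and not a number (the limit of > 100000 nM in this assay, at which 1 of the 3 values shown sits).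

Compound 4, `Cc1cc(/C=C2\SC(=O)NC2=O)c(C)n1-c1ccc(-c2ccc(/C=C3\SC(=O)NC3=O)cc2)cc1`, has not yet been measured. It differs from compound 2 in one place: hydrogen in place of methoxy on an aromatic carbon of a six-membered aromatic ring of carbon only, ortho to a large group and meta to a large group. Both arms of compound 2 are kept. Since a methoxy group is a small change relative to the rest of the molecule, the step is expected to be small, at most a mild weakening, and possibly none beyond the scatter. Compound 4 is expected to give about 3000 nM in this assay, within 1200 nM to 8000 nM, which corresponds to an expected step of a 1.4-fold higher number from compound 2 to compound 4 (0.15 log units; within the scatter).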

Compound 4, half-maximal inhibitory concentration: 1190 nM
Beside the measured number, compound 4's estimate is 2.5-fold (0.40 log units) above it; the measured number lies below the stated range.
By their numbers in this assay, from the lowest: compounds 1, 4 and 2 (each within the scatter of the next, the first and the last beyond it). At a limit, above all of these: compound 3.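

In this assay, replacing the methoxy with hydrogen on this aromatic carbon, ortho to a large group and meta to a large group, gives a 1.8-fold lower number from compound 2 to compound 4 (0.25 log units; within the scatter). Compounds 1 and 2 both carry the methoxy, so they could not show what it contributes; the pair of compound 2 and compound 4 now shows that, in the setting of compound 2, a value in this range does not depend on having the methoxy at this position. Neither compound of the pair can be ranked above the other in this assay.

As far as these compounds go, whether this position accepts other groups, such as an amine, a carboxylic acid or a longer chain, stays open: only methoxy and hydrogen appear here. Nothing measured among these compounds gives a reason for this step.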